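This account rests on a few compounds, and the source may have more. Where it says the series, first, only, none or still open, it means among the compounds named here.

Compound 1, `CCOC(=O)CC(=O)Nc1c(C(C)C)cccc1C(C)C`: 1800 nM
Compound 2, `CCCCCCCCCCCCOC(=O)CC(=O)Nc1c(C(C)C)cccc1C(C)C`: 11 nM
Compound 3, `CC(C)c1cccc(C(C)C)c1NC(=O)CC(=O)OC(C)(C)C`: 130 nM

In an assay on microsomes from intestine for inhibition of acyl-CoA:cholesterol acyltransferase (Oryctolagus cuniculus) (on this read-out lower numbers stand for stronger inhibition and higher numbers for weaker inhibition), compound 3 holds the second highest of the three numbers; it sits a 14-fold lower number from compound 1 to compound 3 (1.14 log units; beyond the scatter) and about as far, in the other direction, from compound 2, whose value is 11 nM. Compound 4, `CCCCCCOC(=O)CC(=O)Nc1c(C(C)C)cccc1C(C)C`, differs from compound 3 in one place: hexyl in place of tert-butyl on an oxygen next to a carbonyl group. Going by the values given here, two measured steps bear on this. The chain on the oxygen was lengthened in one, a 160-fold lower number from compound 1 to compound 2 (2.21 log units; beyond the scatter), and branched in the other, a 14-fold lower number from compound 1 to compound 3 (1.14 log units; beyond the scatter); both lowered the number by a large margin, the longer chain more than the tert-butyl. Hexyl stands between the ethyl of compound 1 and the chain of compound 2, so the number for compound 4 is expected to fall between those of compound 3 and compound 2, a step of a 3.3-fold lower number from compound 3 to compound 4 (0.51 log units; beyond the scatter) downward in this assay. Compound 4 is therefore estimated at 40 nM, within 15 nM to 120 nM.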

Compound 4, half-maximal inhibitory concentration: 810 nM
For compound 4 the middle estimate is 20-fold (1.31 log units) below the measured one; the measured number lies above the stated range.
By their numbers in this assay, from the lowest: compound 2; then compound 3; then compound 4; then compound 1.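

In this assay, lengthening the chain on this oxygen does not lower the number evenly: hexyl gains only modestly over ethyl, a 2.2-fold lower number from compound 1 to compound 4 (0.35 log units; beyond the scatter), and most of the fall comes with the longer chain, a 74-fold higher number from compound 2 to compound 4 (1.87 log units; beyond the scatter). Carbon count alone does not order the series, and compound 3 goes against it: tert-butyl, the smaller of the two groups exchanged here, gives the lower number, a 6.2-fold higher number from compound 3 to compound 4 (0.79 log units; beyond the scatter). Nothing available accounts for this difference.

The compounds shown leave open how the number changes with chain length beyond hexyl, which an octyl or decyl ester would help to settle. They also leave open whether the gain from tert-butyl extends to other branched groups, such as isopropyl, or to a cyclohexyl ester.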